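The source may hold more compounds than are shown below. What is called first, only, known or untested is meant among the compounds shown, and "the series" means these compounds.

Compound 3 `O=C1Nc2ccc(Cl)cc2/C1=N/NC(=S)Nc1ccccc1` is the starting point. In a functional assay on MCF7 cells (Homo sapiens) for inhibition, read by MTT assay, with a stated time of 72 h (a higher number here means a weaker inhibitor, a lower number a stronger inhibitor), compound 3 gives 35000 nM. Its nearest neighbour among the numbers shown is compound 1 `O=C1Nc2ccc(F)cc2/C1=N/NC(=S)N1CCN(c2ccccc2)CC1`, which in this assay gives 24300 nM, a value within the scatter of compound 3, so the two cannot be ranked. Compound 2 `O=C1Nc2ccccc2/C1=N/NC(=S)Nc1ccccc1` reaches only a limit of this assay, > 100000 nM. For the measured compounds named here, the single measured step, an at least 2.8-fold lower number from compound 2 to compound 3 (0.45 log units; beyond the scatter), concerns the chloro on the shared core. Compound 4 `Cc1ccc(NC(=S)N/N=C2\C(=O)Nc3ccc(Cl)cc32)c(C)c1` differs at another place: 2,4-dimethylphenyl in place of phenyl on an amide-type nitrogen. Going by the values given here, no measured step touches that phenyl, so the expected change, a 1.2-fold lower number from compound 3 to compound 4 (0.07 log units; within the scatter), is none beyond the scatter. Compound 4 is therefore estimated at 30000 nM, with a range from 10000 nM to 100000 nM.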

Compound 4, half-maximal inhibitory concentration: > 100000 nM
Compound 4 gave a limit, no number (the forecaster's own chance of this, stated with the estimate: 20%); at least 3.3-fold (0.52 log units) between middle value and limit.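

For the compounds shown here, the phenyl on the amide-type nitrogen, which no earlier step touched, does affect the result: in this assay, replacing it with 2,4-dimethylphenyl while keeping the chloro on the shared core gives an at least 2.8-fold higher number from compound 3 to compound 4 (0.45 log units; beyond the scatter). Compound 4 gives a limit and not a number, so this step has a minimum size but no exact size: the limit of > 100000 nM in this assay, at which 2 of the 4 values shown sit.

Which of the two methyl groups accounts for this change remains open. So does how an amine or a carboxylic acid on this phenyl would behave.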